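The source may report more compounds than this note shows. Statements on the series, on what has been measured and on what is new or still open speak of the compounds shown alone.

Measured so far in a functional assay on SH-SY5Y cells (Homo sapiens) for cytotoxicity, tested at 1 uM; on this read-out higher numbers stand for a weaker effect at the one concentration tested and lower numbers for a stronger effect:

compound 1, `O=C(CCCCCCn1cc(-c2cccnc2)nn1)Nc1ccccc1Cc1ccccc1`: 28%
compound 2, `O=C(CCCCCCCn1cc(-c2cccnc2)nn1)Nc1ccccc1Cc1ccccc1`: 30%
compound 3, `O=C(CCCCCCn1cc(-c2cccnc2)nn1)Nc1ccccc1Oc1ccccc1`: 24.7%

Compound 1 and compound 3 differ in one place: phenoxy in place of benzyl on an aromatic carbon. In this assay that change gave a number 3.3 percentage points lower from compound 1 to compound 3 (within the scatter), so the two compounds cannot be told apart on this read-out. Compound 2 shares its core with compound 4, `O=C(CCCCCCCn1cc(-c2cccnc2)nn1)Nc1ccccc1Oc1ccccc1`, and the difference between the cores of compound 1 and compound 2 is not broken down here. Compound 4 carries the same change as compound 3: phenoxy in place of benzyl on an aromatic carbon. The expected step in this assay is a number 3 percentage points lower from compound 2 to compound 4 (within the scatter), resting on the earlier a number 3.3 percentage points lower from compound 1 to compound 3 (within the scatter), which stayed within the usual scatter. Compound 4 is therefore estimated to give about 27%, most likely between 17% and 37%.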

Compound 4, a percentage reported as activity, at one concentration (the size of the read-out at that concentration, not a potency): 17.7%
The estimate for compound 4 lay 9.3 percentage points above the measured number, within the range that was stated.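

In this assay phenoxy in place of benzyl gave a number 12.3 percentage points lower from compound 2 to compound 4 (beyond the scatter) and so clears the usual scatter on this core. Set beside the same change on the core of compound 1, the two steps cannot be told apart: the same change on two cores in this assay, a number 3.3 percentage points lower (within the scatter) from compound 1 to compound 3 and a number 12.3 percentage points lower (beyond the scatter) from compound 2 to compound 4, 9 percentage points apart, within the scatter of two such steps. The change therefore carries from one core to the other without a demonstrable difference in size, but two cores, only one of them with a step beyond the scatter, do not show that it would hold on other cores, nor why the number falls.

The compounds shown leave open what an amine or a carboxylic acid would do in place of phenoxy on that aromatic carbon. They also leave open whether the step persists with a longer chain.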